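The source may report more compounds than this note shows. Statements on the series, on what has been measured and on what is new or still open speak of the compounds shown alone.

In a functional assay on HCT-116 cells (Homo sapiens) for antiproliferative activity, read by MTT assay, with a stated time of 24 h (a lower number here means a stronger inhibitor, a higher number a weaker inhibitor), compound 1 `COc1cc(OC)c(-c2coc3cc(OCc4ccc(F)cc4)ccc3c2=O)cc1OC` gives 950 nM, compound 2 `COc1cc(OC)c(-c2coc3cc(OCc4ccccc4C)ccc3c2=O)cc1OC` gives 2900 nM and compound 3 `COc1cc(OC)c(-c2coc3cc(OCc4ccc(C#N)cc4)ccc3c2=O)cc1OC` gives 4220 nM. The upper end of this small range is shared: a 1.5-fold higher number from compound 2 to compound 3 (0.16 log units; within the scatter) stays within the scatter, while a 4.4-fold higher number from compound 1 to compound 3 (0.65 log units; beyond the scatter) goes beyond it.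

The next case is compound 4 `COc1cc(OC)c(-c2coc3cc(OCc4ccccc4Cl)ccc3c2=O)cc1OC`, and the change is 2-chlorophenyl in place of 4-cyanophenyl on a saturated chain carbon bound to an oxygen on an aromatic ring. All three measured steps bear on it, as each alters the group at this same place. The largest, a 4.4-fold higher number from compound 1 to compound 3 (0.65 log units; beyond the scatter), and the smaller 3.1-fold higher number from compound 1 to compound 2 (0.48 log units; beyond the scatter) are both modest and both start from the 4-fluorophenyl group of compound 1. Within the data shown here, the 2-chlorophenyl group itself has no measured precedent, and the nearest measured group by name is the 2-methylphenyl of compound 2, at 2900 nM. In this assay, a slightly lower number is therefore expected, with no change beyond the scatter. The expected step is a 1.5-fold lower number from compound 3 to compound 4 (0.18 log units; within the scatter). Compound 4 is estimated at 2800 nM, within an expected range of 1100 nM to 6500 nM.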

Compound 4, half-maximal inhibitory concentration: 2450 nM
Compound 4: the middle estimate sits 1.1-fold (0.06 log units) above what was measured; measured number inside the range.
By their numbers in this assay, from the lowest: compound 1; then compounds 4, 2 and 3 (each within the scatter of the next).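

In this assay the 2-chlorophenyl group falls in with the 2-methylphenyl and 4-cyanophenyl groups, with a 1.7-fold lower number from compound 3 to compound 4 (0.24 log units; within the scatter) and a 1.2-fold lower number from compound 2 to compound 4 (0.07 log units; within the scatter) both printed within the scatter, so chloro in place of methyl on the aromatic carbon gives no resolved difference here. With a 2.6-fold higher number from compound 1 to compound 4 (0.41 log units; beyond the scatter) beyond the scatter, compound 1 now separates from all three other compounds and holds the lowest number, while compound 3 shows that a group named as 4-substituted does not by itself share that standing. No measured evidence bears on this grouping or on the separation of compound 1.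

On these data alone, whether 4-chlorophenyl on this carbon would stand with compound 1 or with the other three remains open. Also open, as far as these compounds go, is how an unsubstituted phenyl, an amine or a longer chain at this place would read.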